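Aryl swap at the hydrazone terminus of the terpenoid series

The compounds below may be only part of what the source reports. "The series", "measured", "known", "first", "only" and "open" are said of these compounds alone.

The series shares the core of compound 1, `CC1=CC[C@@H]([C@@](C)(O)CCCC(C)(C)NC(=S)NN)CC1`. In a functional assay on MCF7 cells (Homo sapiens) for cytotoxicity, read by sulforhodamine B assay (a higher number here means a weaker inhibitor of growth, a lower number a stronger inhibitor of growth), compound 1 gives 84200 nM. Compound 2, `CC1=CC[C@@H]([C@@](C)(O)CCCC(C)(C)NC(=S)N/N=C\c2ccc([N+](=O)[O-])cc2)CC1`, carries a 4-nitrophenyl group on the carbon with a double bond to nitrogen. For compound 2 this assay records only a limit, > 100000 nM, and no number; this is the limit of > 100000 nM in this assay, at which 1 of the 2 values shown sits. Compound 3, `CC1=CC[C@@H]([C@@](C)(O)CCCC(C)(C)NC(=S)N/N=C\c2ccccc2Cl)CC1`, changes that aryl group: 2-chlorophenyl in place of 4-nitrophenyl on a carbon with a double bond to nitrogen. For the measured compounds named here, no step between two measured compounds exists in this assay to calibrate a change of this kind, and the two values shown give only a weak number for compound 1 and a limit for compound 2. The step of a number no higher from compound 2 to compound 3 (the limit leaves the size open) is expected to be none beyond the scatter. Compound 3 is therefore estimated at 100000 nM, within a range of 40000 nM to 250000 nM, with a real chance that this assay again reports only a limit.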

Compound 3, concentration for total growth inhibition: > 100000 nM
Compound 3: no number, only a limit (the forecaster's own chance of this, stated with the estimate: 50%); the middle value sits exactly at the limit.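

In this assay compound 3 also returns only a limit, > 100000 nM, so a second aryl group at this position gives no number, and the step between the two limits cannot be read. For the compounds shown here, the one readable step is an at least 1.1-fold higher number from compound 1 to compound 3 (0.07 log units; that floor lies within the scatter), so this change shows no shift beyond the scatter. Readings at this position now gather at one end of the read-out: the limit of > 100000 nM in this assay, at which 2 of the 3 values shown sit.

From the compounds shown here alone, whether any aryl group on the carbon with a double bond to nitrogen gives a number rather than a limit stays open. Going by these compounds, how a 4-aminophenyl group, or a phenyl ring carrying a carboxylic acid, would read at this position also stays open.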